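This account rests on a few compounds, and the source may have more. Where it says the series, first, only, none or still open, it means among the compounds named here.

Two compounds of the series have been run in a functional assay on HepG2 cells (Homo sapiens) for cytotoxicity, read by MTT assay, with a stated time of 48 h (a lower number here means a stronger inhibitor, a higher number a weaker inhibitor), so far. Compound 1 `CSc1nnc(C)n1N1C(=O)c2ccccc2C1=O` is the smaller of the pair. In this assay compound 1 returns no number but only a limit, > 200000 nM. Compound 2 `CCc1nnc(SCC(=O)c2ccccc2)n1N1C(=O)c2ccccc2C1=O` extends the sulfur-bound chain. In this assay compound 2 likewise returns only a limit, > 200000 nM. Where compound 2 stands is therefore not a value at all, and the sole evidence on the set is the limit of > 200000 nM in this assay, at which 2 of the 2 values shown sit. Among the measured compounds shown here, no step between measured compounds can be computed, since no measured pair differs in a single place.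

Compound 3 `CCc1nnc(SC)n1N1C(=O)c2ccccc2C1=O` is not yet measured. It differs from compound 2 in one place: hydrogen in place of benzoyl on a saturated chain carbon bound to a sulfur. Both measured compounds sit at the limit, so no step beyond the scatter is expected in this assay from that change. The expected step is a number no higher from compound 2 to compound 3 (the limit leaves the size open), an estimate that amounts to no movement. Compound 3 is estimated at 200000 nM, within 100000 nM to 500000 nM, and is expected most likely to be reported once more as a limit rather than a number.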

Compound 3, half-maximal inhibitory concentration: > 200000 nM
Compound 3 gave a limit, no number (the forecaster's own chance of this, stated with the estimate: 85%); the middle value sits exactly at the limit.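

Neither the step from compound 2 to compound 3 nor the step from compound 1 to compound 3 can be read, as all three compounds return only a limit in this assay: the limit of > 200000 nM in this assay, at which 3 of the 3 values shown sit.

The compounds shown leave open whether any member of the series gives a number rather than a limit in this assay, and what benzoyl contributes there.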